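A few compounds are considered here, and "the series" means these few. Any claim that something is new, unique, unknown or untested is made for them only; others in the source may bear on it.

Compound 1 `COc1ccc(-c2scc3c(N4CC[C@@H](NC(C)=O)C4)nc(C)nc23)cc1OC`: > 95% (a limit)
Compound 2 `COc1cc(-c2c(C)nc3c(N4CC[C@@H](NC(C)=O)C4)cc(C)nn23)cc(OC)c1OC`: > 95% (a limit)
Compound 3 `COc1ccc(-c2c(C)nc3c(N4CC[C@@H](NC(=O)NC(C)C)C4)cc(C)nn23)cc1OC`: > 95% (a limit)

In an ADME assay on microsomes from liver (Mus musculus) for metabolic stability, read by LC-MS, with NADPH named in the record, with a stated time of 60 min, tested at 1 uM, in the absence of a further agent (on this read-out higher numbers stand for a more stable compound and lower numbers for a less stable compound), compound 3 gives only a limit, > 95%. Among the compounds with values here, the same holds for the whole set, since (the limit of > 95% in this assay, at which 3 of the 3 values shown sit); no step between measured compounds is resolved, so compound 3 cannot be ranked against compound 1 or compound 2 beyond saying that all three reach the limit.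

Compound 4 `COc1ccc(-c2c(C)nc3c(N4CCCC4)cc(C)nn23)cc1OC` is the next compound to be measured in this assay. Against compound 3 it differs in one place: hydrogen in place of (isopropylcarbamoyl)amino on a saturated ring carbon. With every measured compound sitting at the limit, no trend on this change can be read from the data. The expected step from compound 3 to compound 4 is a number at least 10 percentage points lower from compound 3 to compound 4 (that floor lies within the scatter), not beyond the scatter. Compound 4 is expected to give about 85%, between 55% and 97%.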

Compound 4, percent of the compound remaining: > 95%
Compound 4 gave a limit, no number; the forecaster's own chance of this, stated with the estimate: 45%; middle value at least 10 percentage points away from the limit.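

Compound 3 and compound 4 both sit at a limit in this assay, so no step between them can be read: the limit of > 95% in this assay, at which 4 of the 4 values shown sit.

Whether hydrogen in place of (isopropylcarbamoyl)amino changes the percent remaining at all stays open, as does any ranking of the compounds shown.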